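This account rests on a few compounds, and the source may have more. Where it says the series, first, only, none or still open, it means among the compounds named here.

In a functional assay on K562 cells (Homo sapiens) for antiproliferative activity, read by MTT assay, with a stated time of 24 h (a lower number here means a stronger inhibitor, a higher number a weaker inhibitor), compound 1 `COC(=O)c1scc(-c2ccc(NC(=O)c3cccc(C(F)(F)F)c3)cc2)c1OC` gives 6130 nM and compound 2 `COC(=O)c1scc(-c2ccc(NC(=O)c3ccc(F)c(Cl)n3)cc2)c1OC` gives 8250 nM, two values within the scatter of each other. Among the compounds with values here, the only measured step is a 1.3-fold higher number from compound 1 to compound 2 (0.13 log units; within the scatter), and it exchanges the whole group on the carbonyl carbon. Compound 3 `COC(=O)c1scc(-c2ccc(NC(=O)c3cccc(OC(F)(F)F)c3)cc2)c1OC` keeps the rest of compound 1 and has trifluoromethoxy in place of trifluoromethyl on an aromatic carbon. This smaller exchange has not been measured directly, so the expected step is a 1.1-fold higher number from compound 1 to compound 3 (0.03 log units; within the scatter), with nothing expected beyond the scatter. The estimated value for compound 3 is 6500 nM, within a range of 3000 nM to 14000 nM.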

Compound 3, half-maximal inhibitory concentration: 18300 nM
Compound 3: the middle estimate sits 2.8-fold (0.45 log units) below what was measured; measured number outside the range, above it.
By their numbers in this assay, from the lowest: compounds 1 and 2 (each within the scatter of the next); then compound 3.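

In this assay, the exchange of trifluoromethyl for trifluoromethoxy on this aromatic carbon gives a 3.0-fold higher number from compound 1 to compound 3 (0.47 log units; beyond the scatter). So a change of one small group here moves the number beyond the scatter, which the whole-group exchange on the carbonyl carbon did not do. Nothing measured here explains this difference.

Whether the added oxygen alone accounts for the step remains open. A methoxy group or an amine on the same aromatic carbon would show whether other groups at this position follow compound 1 or compound 3.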